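Swapping methoxymethyl for hydroxymethyl on one side chain

The compounds below may be only part of what the source reports. "The series", "measured", "known", "first", "only" and "open" are said of these compounds alone.

Compound 1 `COC[C@H](C)[C@H](C)C(c1ccc(O)c(OC)c1)c1ccc(O)c(OC)c1`: 72000 nM
Compound 2 `COc1cc(C(c2ccc(O)c(OC)c2)[C@H](C)C(C)C)ccc1O`: 16000 nM

In a functional assay on HeLa cells (Homo sapiens) for cytotoxicity, read by WST assay, with a stated time of 48 h (a lower number here means a stronger inhibitor, a higher number a weaker inhibitor), compound 1 has the higher of the two numbers, making it the weaker inhibitor. Compound 3 `COc1cc(C(c2ccc(O)c(OC)c2)[C@H](C)[C@H](C)CO)ccc1O` differs from it at a single place, on a saturated chain carbon bound to two aromatic carbons: 2-(hydroxymethyl)-1-methylpropyl in place of 2-(methoxymethyl)-1-methylpropyl on a saturated chain carbon bound to two aromatic carbons. Among the measured compounds shown here, only one measured step changes this same place: a 4.5-fold lower number from compound 1 to compound 2 (0.65 log units; beyond the scatter). That step installs a different group, so it offers only a rough guide to size. A smaller step toward a lower number is expected in this assay, perhaps not clearly beyond the scatter. The expected step is a 1.8-fold lower number from compound 1 to compound 3 (0.26 log units; within the scatter). The estimated value for compound 3 is 40000 nM, expected to fall within 15000 nM to 90000 nM.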

Compound 3, half-maximal inhibitory concentration: > 100000 nM
Compound 3 gave a limit, no number; the forecaster's own chance of this, stated with the estimate: 10%; at least 2.5-fold (0.39 log units) between middle value and limit.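

In this assay, compound 3 gives a limit, not a number: the limit of > 100000 nM in this assay, at which 1 of the 3 values shown sits. Replacing 2-(methoxymethyl)-1-methylpropyl with 2-(hydroxymethyl)-1-methylpropyl brings no sign of a lower number, only an at least 1.3-fold higher number from compound 1 to compound 3 (0.14 log units; that floor lies within the scatter), a floor that does not separate the two compounds. Hydroxy in place of hydrogen has a clearer effect on the number, with an at least 6.2-fold higher number from compound 2 to compound 3 (0.79 log units; beyond the scatter).

Going by these compounds, the true size of both steps remains open, as neither has an upper bound. Also open, on these data alone, is how this assay would read a side chain carrying an amine or a carboxylic acid.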